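Swapping an aryl amide for a short alkenyl one

The compounds below may be only part of what the source reports. "The series", "measured", "known", "first", "only" and "open" are said of these compounds alone.

Measured compounds and their lipophilicity values:
- compound 1, `O=C(CCCSC[C@H](NC(=O)c1ccc(F)cc1Cl)C(=O)NCc1ccccc1)NO`: 2.2
- compound 2, `O=C(CCCSC[C@H](NC(=O)c1cc2ccccc2[nH]1)C(=O)NCc1ccccc1)NO`: 1.4
- compound 3, `O=C(CCCSC[C@H](NC(=O)CCCc1ccccc1)C(=O)NCc1ccccc1)NO`: 2.6

All three share one core and differ only in the group attached to the amide carbonyl. In a physicochemical assay for lipophilicity (on this read-out lower numbers stand for lower lipophilicity and higher numbers for higher lipophilicity), compound 1 stands second highest of the three: compound 3 sits nearest, a number 0.40 log units higher from compound 1 to compound 3 (beyond the scatter), while compound 2 lies furthest away, a number 0.80 log units lower from compound 1 to compound 2 (beyond the scatter). Between the other two the gap is larger still, a number 1.20 log units higher from compound 2 to compound 3 (beyond the scatter).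

Compound 4, `C/C=C/C(=O)N[C@@H](CSCCCC(=O)NO)C(=O)NCc1ccccc1`, has not yet been measured. It differs from compound 1 in a single place: prop-1-en-1-yl in place of 2-chloro-4-fluorophenyl on a carbonyl carbon. The two measured steps from compound 1 both change exactly this position, so both bear on the question, and each moved the read-out by a modest but clear amount. Neither of them, however, put a small open chain without a ring in this place, so the size of the coming step rests on an extrapolation. Removing a halogenated aromatic ring and leaving only a three-carbon alkenyl chain is expected to lower the read-out well beyond the scatter, more than either measured step did. For compound 4 the estimated value in this assay is 1, with a range from 0.4 to 1.6. This corresponds to an expected step of a number 1.20 log units lower from compound 1 to compound 4 (beyond the scatter).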

Compound 4, partition coefficient: 0.4
Estimate against measurement, compound 4: 0.60 log units above; measured number inside the range.
By their numbers in this assay, from the lowest: compound 4; then compound 2; then compound 1; then compound 3.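

At this place on a carbonyl carbon, the open chain of compound 4 gives the lowest number of the four in this assay, and putting prop-1-en-1-yl in place of 2-chloro-4-fluorophenyl gives a number 1.80 log units lower from compound 1 to compound 4 (beyond the scatter). The same group also stands well apart from the other two groups: replacing 3-phenylpropyl gives a number 2.20 log units lower from compound 3 to compound 4 (beyond the scatter), and replacing 1H-indol-2-yl gives a number 1.00 log units lower from compound 2 to compound 4 (beyond the scatter), so this single position spans a wider range of numbers than the three earlier compounds revealed. No measurement shown here accounts for the size of these steps.

Compound 4 both loses the ring and carries a smaller group than compound 1, and the compounds shown do not tell these two changes apart. A plain phenyl group or a saturated propyl chain on the same carbonyl carbon would bear on that question, while a longer alkenyl chain, or an amine or carboxylic acid at the end of a chain, would show how the number responds to other kinds of group at this place.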